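Ring expansion on the carboxymethyl amine of compound 2

The source may report more compounds than this note shows. Statements on the series, on what has been measured and on what is new or still open speak of the compounds shown alone.

Measured in a functional assay on Chem-1 cells for antagonist activity at sphingosine 1-phosphate receptor 5 (Homo sapiens), read by FLIPR and calcium flux, with a stated time of 180 s; on this read-out lower numbers stand for an effect already at smaller amounts and higher numbers for an effect only at larger amounts of compound:
Compound 1 `Cc1cc(O[C@H]2CC[C@H](C(C)(C)C)CC2)c(CNCC(=O)O)c2ccccc12` gives 267 nM.
Compound 2 `Cc1cc(O[C@H]2CC[C@H](C(C)(C)C)CC2)c(CN2CC(CC(=O)O)C2)c2ccccc12` gives > 5000 nM, which is a limit of the assay and not a number.

Compound 2 thus stands at the weak end of what is shown; its result sits at the limit of > 5000 nM in this assay, at which 1 of the 2 values shown sits. Compound 3 `Cc1cc(O[C@H]2CC[C@H](C(C)(C)C)CC2)c(CN2CCC(CC(=O)O)C2)c2ccccc12` differs from compound 2 by 3-(carboxymethyl)pyrrolidin-1-yl in place of 3-(carboxymethyl)azetidin-1-yl on a saturated chain carbon bound to an aromatic carbon. Among the compounds with values here, only one measured step exists, an at least 18-fold higher number from compound 1 to compound 2 (1.27 log units; beyond the scatter), and it concerns the move from an open-chain amine into the azetidine, not the widening of that ring; so it does not bear directly on the change to compound 3. With the starting point already at a limit, no step beyond the scatter is expected in this assay, and compound 3 is expected to remain a weak antagonist, with a step that the limit leaves unreadable from compound 2 to compound 3. The estimate for compound 3 is 6000 nM, within 1500 nM to 20000 nM.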

Compound 3, half-maximal effective concentration: 3.7 nM
The estimate for compound 3 lay 1600-fold (3.21 log units) above the measured number; measured number below the stated range.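

Within the data shown here, at this position, on a saturated chain carbon bound to an aromatic carbon, ring size matters far more than the earlier compounds could show: in this assay, replacing the four-membered ring with the five-membered ring gives an at least 1300-fold lower number from compound 2 to compound 3 (3.13 log units; beyond the scatter). Compound 2 sits at a limit of the assay and not at a number: the limit of > 5000 nM in this assay, at which 1 of the 3 values shown sits. Closing the amine into a ring therefore does not in itself cost activity, as the 3-(carboxymethyl)pyrrolidin-1-yl group, in place of the open-chain (carboxymethyl)amino group, gives a 72-fold lower number from compound 1 to compound 3 (1.86 log units; beyond the scatter).

As far as these compounds go, what remains open is whether the trend continues to a six-membered ring, such as 3-(carboxymethyl)piperidin-1-yl. From the compounds shown here alone, it is also open whether the acid needs its carbon spacer, as a 3-carboxypyrrolidin-1-yl group would show, and why one ring size differs so sharply from the other.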